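The source may hold more compounds than are shown below. What is called first, only, known or untested is meant among the compounds shown, and "the series" means these compounds.

Measured so far:
Compound 1 `O=C(N1CCC(F)CC1)N1CC(c2nc(-c3cccc(Cl)c3)no2)C1`: 990 nM
Compound 2 `O=C(C1CCC(C(F)(F)F)CC1)N1CC(c2nc(-c3cccc(F)c3)no2)C1`: 680 nM

Within the data shown here, only two compounds carry a number in an assay on HEK293 cells for positive allosteric modulation of metabotropic glutamate receptor 5 (Homo sapiens), read by FLIPR; on this read-out lower numbers stand for an effect already at smaller amounts and higher numbers for an effect only at larger amounts of compound. Compound 1 gives 990 nM, the higher of the two numbers; compound 2 gives 680 nM, and the gap between them lies within the scatter, so the two values are read as equivalent. Among the measured compounds shown here, no step between compounds that differ in a single place is available, and the two measured compounds differ in more than one place, so no single change has yet been tied to a change in the read-out.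

Compound 3 `CC1CN(C(=O)N2CC(c3nc(-c4cccc(Cl)c4)no3)C2)CC(C)O1` is not yet measured. It derives from compound 1 by a single change: 2,6-dimethylmorpholin-4-yl in place of 4-fluoropiperidin-1-yl on a carbonyl carbon.

Nothing in the measured pair speaks for or against this change. The working expectation for this assay is a step from compound 1 to compound 3 of no more than modest size, in either direction, with no strong case for a move beyond the scatter; the estimated step is a 1.1-fold higher number from compound 1 to compound 3 (0.05 log units; within the scatter). Compound 3 is therefore expected to give about 1100 nM, within a range of 350 nM to 3500 nM.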

Compound 3, half-maximal effective concentration: > 10000 nM
Compound 3 gave a limit, no number; the forecaster's own chance of this, stated with the estimate: 10%; middle value at least 9.0-fold (0.95 log units) from the limit.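

In this assay, the group on this carbonyl carbon is not freely exchangeable among six-membered non-aromatic rings: 2,6-dimethylmorpholin-4-yl in place of 4-fluoropiperidin-1-yl gives an at least 10-fold higher number from compound 1 to compound 3 (1.00 log units; beyond the scatter). The earlier pair differs in more than one place and tied no change to the read-out, whereas this single change moves the read-out beyond the scatter and so marks this position as one that can decide the outcome in this assay. Compound 3 stands at a limit of the assay and not at a number, and the step can be read only as a minimum: the limit of > 10000 nM in this assay, at which 1 of the 3 values shown sits.

The change removes the fluorine and brings in a ring oxygen and two methyl groups all at once, so the compounds shown do not tell which of these parts carries the step. Unsubstituted morpholin-4-yl or plain piperidin-1-yl on the same carbonyl carbon would separate these parts, and how either would compare with compound 1 remains open.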